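Acetyl for cyclohexyl on the shared core: prospective note

The compounds below may be only part of what the source reports. "The series", "measured", "known", "first", "only" and "open" are said of these compounds alone.

Measured so far:
- compound 1 `CCCCCCCCCCCCOc1cccc(N2C(N)=NC(N)=NC2(C)C)c1` gives 6.41 in a functional assay on L5178Y cells (Mus musculus) for inhibition; on this read-out higher numbers stand for higher potency (the scale is a negative logarithm) and lower numbers for lower potency
- compound 2 `CC1(C)N=C(N)N=C(N)N1c1cccc(C2CCCCC2)c1` gives 7.97 in this assay
- compound 3 `CC1(C)N=C(N)N=C(N)N1c1cccc(COc2cccc(NC(=N)S)c2)c1` gives 8.08 in this assay

Compound 2 holds the second highest of the three numbers in this assay. Its nearest neighbour is compound 3, whose number lies a little higher but within the usual scatter, so the two cannot be ordered. For the measured compounds named here, compound 1 lies furthest away, its number clearly lower and beyond the scatter; the side group of compound 1 is a long chain, that of compound 2 a carbon ring, that of compound 3 a further aromatic arm, and no single-site pair exists among them.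

Compound 4 `CC(=O)c1cccc(N2C(N)=NC(N)=NC2(C)C)c1` is not yet measured. It differs from compound 2 in one place: acetyl in place of cyclohexyl on an aromatic carbon. Going by the values given here, nothing measured here carries an acetyl, so the step has no precedent; the only guide is that the small change from the carbon ring of compound 2 to the long chain of compound 1 went with a markedly lower number: compound 1 gives 6.41, whereas compound 2 gives 7.97.

For compound 4 a drop beyond the scatter is expected, with an estimated step of a number 1.47 log units lower from compound 2 to compound 4 (beyond the scatter) in this assay. The estimate for compound 4 is 6.5, with a range from 5.7 to 7.3.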

Compound 4, logarithm of the reciprocal of the active concentration, log(1/C): 6.96
The estimate for compound 4 lay 0.46 log units below the measured number, within the range that was stated.
By their numbers in this assay, from the lowest: compound 1; then compound 4; then compounds 2 and 3 (each within the scatter of the next).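

In this assay, for the compounds shown here, acetyl in place of cyclohexyl gives the first step at a single site (a number 1.01 log units lower from compound 2 to compound 4 (beyond the scatter)), which shows that the group on this aromatic carbon, meta to a large group, affects the read-out. The step is large, yet compound 4 still gives 6.96, so a cyclohexyl ring at this place is not required for potency at that level. Because the change removes a six-membered non-aromatic ring, lowers the heavy-atom count and adds a hydrogen-bond acceptor all at once, the step cannot be assigned to any one of these, and nothing measured here explains it.

Still open, from the compounds shown here alone, is which of these differences carries the step: an isopropyl or cyclopropyl group at the same place would test carbon groups without the carbonyl, while a cyclohexylcarbonyl group would keep the ring and add the carbonyl. Also open, going by these compounds, is how a phenyl ring, an amine or a carboxylic acid at this place would compare with cyclohexyl and acetyl on the shared core.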